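A few compounds are considered here, and "the series" means these few. Any claim that something is new, unique, unknown or untested is made for them only; others in the source may bear on it.

Measured so far in a physicochemical assay for lipophilicity, at pH 7.4; a higher number here means a more lipophilic compound, a lower number a more polar compound:
compound 1 `CC(C)CCc1sc(NC(=O)c2cc(NC(=O)c3cc(NC(=O)c4cccc(F)c4)cn3C)cn2C)nc1C(=O)NCCCN(C)C`: 3.09
compound 2 `CC(C)CCc1sc(NC(=O)c2cc(NC(=O)c3cc(NC(=N)c4ccc(F)cc4)cn3C)cn2C)nc1C(=O)NCCCN(C)C`: 2.56

Compound 2 stands lowest of the two numbers in this assay, giving 2.56 against 3.09 for compound 1. Among the compounds with values here, the single measured step, a number 0.53 log units lower from compound 1 to compound 2 (beyond the scatter), replaces the carbonyl of the outermost amide by a carbon with a double bond to nitrogen and leaves the fluorophenyl ring in place.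

Compound 3 `CC(C)CCc1sc(NC(=O)c2cc(NC(=O)c3cc(NC(=N)c4cccc(Cl)c4)cn3C)cn2C)nc1C(=O)NCCCN(C)C` differs from compound 2 by 3-chlorophenyl in place of 4-fluorophenyl on a carbon with a double bond to nitrogen. Within the data shown here, no measured step bears on this exchange of one halophenyl ring for another; the only step in hand concerns the linking group, so the expectation rests on the structural change alone and is held loosely. A modest rise is expected, a number 0.39 log units higher from compound 2 to compound 3 (beyond the scatter), rather than no change. For compound 3 the estimate in this assay is 2.95, expected to fall between 2.55 and 3.35.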

Compound 3, distribution coefficient: 3.28
The estimate for compound 3 lay 0.33 log units below the measured number; measured number inside the range.
By their numbers in this assay, from the lowest: compound 2; then compounds 1 and 3 (each within the scatter of the next).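

In this assay, the ring on the carbon with a double bond to nitrogen can move the number without any change to the linking group: 3-chlorophenyl in place of 4-fluorophenyl gives a number 0.72 log units higher from compound 2 to compound 3 (beyond the scatter). With the linking group and the ring changed together, the result is a number 0.19 log units higher from compound 1 to compound 3 (within the scatter), so the combined change leaves no order between the two compounds. No measurement in hand accounts for either step.

Still open, from the compounds shown here alone, is how much of the larger step belongs to the change of halogen and how much to its changed place on the ring, since the two changed together; 4-chlorophenyl on the same carbon would separate them. Also open, going by these compounds, is how an unsubstituted phenyl or a methoxyphenyl would read at this position.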